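The source may hold more compounds than are shown below. What is called first, only, known or untested is meant among the compounds shown, and "the series" means these compounds.

The series shares one core, seen in compound 1 `CCCc1c(OCCCCOc2ccc(-c3nn[nH]n3)cc2)ccc2c1cnn2CC(C)(C)C`, compound 2 `CCCCCn1ccc2c(CCC)c(OCCCCOc3ccc(-c4nn[nH]n4)cc3)ccc21` and compound 3 `CC(C)(C)Cn1ccc2cc(OCCCCOc3ccc(-c4nn[nH]n4)cc3)ccc21`, each carrying the same tetrazolylphenoxy-butoxy chain. In a functional assay for binding affinity to metabotropic glutamate receptor 2 (Homo sapiens), read by GTPgammaS binding, with a stated time of 1 h, at 30 degrees C (a lower number here means that less compound is needed, a higher number that more compound is needed for the effect), compound 1 gives 984 nM and compound 2 gives 598 nM. Compound 1 bears a propyl group where compound 3 bears hydrogen; in this assay compound 3 gives 3590 nM, the highest of the three numbers; its gaps to compound 1 and to compound 2 both lie beyond the scatter, so compound 3 is the weakest of the measured set.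

Compound 4 `CC(C)(C)Cn1ccc2c(Br)c(OCCCCOc3ccc(-c4nn[nH]n4)cc3)ccc21` differs from compound 3 in one place: bromo in place of hydrogen on an aromatic carbon. Among the compounds with values here, no step between two measured compounds matches this change exactly, so the expectation rests on what the measured numbers show. Because compound 3 gives 3590 nM while compound 1 gives 984 nM, filling this aromatic carbon with a heavy substituent appears to favour a lower number, and bromo is expected to act in the same direction. The step from compound 3 to compound 4 is therefore expected to be a 2.8-fold lower number from compound 3 to compound 4 (0.44 log units; beyond the scatter), a decrease beyond the scatter. On that basis compound 4 is estimated at 1300 nM in this assay, with a plausible range from 500 nM to 3500 nM.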

Compound 4, half-maximal effective concentration: 2260 nM
Compound 4: middle estimate off by 1.7-fold (0.24 log units), on the low side; measured number inside the range.
By their numbers in this assay, from the lowest: compounds 2 and 1 (each within the scatter of the next); then compounds 4 and 3 (each within the scatter of the next).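

Within the data shown here, the step of bromo in place of hydrogen on this aromatic carbon, ortho to a fused ring and ortho to a large group, is a 1.6-fold lower number from compound 3 to compound 4 (0.20 log units; within the scatter) in this assay and is the first direct reading at this position. It shows that a single bromine atom here, the only heavy atom that enters, leaves the number within the usual scatter, so the change in this assay cannot be told from repeat measurement and compound 3 and compound 4 must be treated as equal in it. No measurement on these compounds offers an explanation for this result.

Compound 1 and compound 2 carry a propyl group on this carbon, but each differs from compound 4 in more than one place, so neither shows what a propyl group does at this position with everything else held fixed. As far as these compounds go, whether a chloro group, a methoxy group, an amine or a carboxylic acid on the same carbon would move the number beyond the scatter remains open, as does whether bromo would behave in the same way on the core of compound 1.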